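The source may report more compounds than this note shows. Statements on the series, on what has been measured and on what is new or still open speak of the compounds shown alone.

Within the data shown here, in an ADME assay for permeability, using PAMPA, with a stated time of 30 min, at pH 7.4 (a higher number here means that the compound crosses the layer faster, a lower number that the compound crosses the layer more slowly), compound 3 (`COc1ccccc1Oc1ccc2c(NCCCNCc3cccc(OC)c3O)ccnc2c1`) gives 317 10^-6 cm/s, the highest of the three numbers so far and beyond the scatter of both others. Compound 1 (`COc1cccc(CNCCCNc2ccnc3cc(C4CCCCC4)ccc23)c1O`) gives 23 10^-6 cm/s, and compound 2 (`COc1ccc(F)cc1CNCCCNc1ccnc2cc(Cc3ccc(F)cc3Cl)ccc12`) gives 23 10^-6 cm/s.

The next structure is compound 4 (`COc1cccc(CNCCCNc2ccnc3cc(Cc4ccc(F)cc4Cl)ccc23)c1O`), with 2-chloro-4-fluorobenzyl in place of 2-methoxyphenoxy on an aromatic carbon.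

Among the measured compounds shown here, one measured step bears directly on this position. It is a 14-fold higher number from compound 1 to compound 3 (1.14 log units; beyond the scatter), a large step on exchanging cyclohexyl for 2-methoxyphenoxy. For the measured compounds named here, compound 3 is the only measured compound carrying 2-methoxyphenoxy, so the high number rests on a single data point. Compound 2 already carries 2-chloro-4-fluorobenzyl but differs from compound 4 elsewhere in the structure, so compound 2 at 23 10^-6 cm/s is indirect evidence. Going by the values given here, no measured step isolates the entering group.

With compound 1 at 23 10^-6 cm/s and compound 2 at 23 10^-6 cm/s, a large step to a lower number is expected on leaving compound 3, similar in size to the one measured at this position. The expected change, as an estimate, is a 9.1-fold lower number from compound 3 to compound 4 (0.96 log units; beyond the scatter). The estimate for compound 4 is 35 10^-6 cm/s, with an expected range from 10 10^-6 cm/s to 120 10^-6 cm/s.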

Compound 4, apparent permeability: 23 10^-6 cm/s
For compound 4 the middle estimate is 1.5-fold (0.18 log units) above the measured one; low and high end bracket the measured number.
By their numbers in this assay, from the lowest: compounds 1, 2 and 4 (each within the scatter of the next); then compound 3.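

In this assay the exchange of 2-methoxyphenoxy for 2-chloro-4-fluorobenzyl on this aromatic carbon gives a 14-fold lower number from compound 3 to compound 4 (1.14 log units; beyond the scatter) as a second large step at the position, so the high number of compound 3 no longer stands out against cyclohexyl alone. Among these compounds, the exchange of cyclohexyl for 2-chloro-4-fluorobenzyl at the same carbon gives no change at the digits printed from compound 1 to compound 4 (within the scatter) in the same assay, so among the three groups compared here only 2-methoxyphenoxy stands apart, on the single data point of compound 3. Among the compounds shown here, with 2-chloro-4-fluorobenzyl held in place, the exchange of 5-fluoro-2-methoxyphenyl for 2-hydroxy-3-methoxyphenyl on a saturated chain carbon bound to an amine nitrogen gives no change at the digits printed from compound 2 to compound 4 (within the scatter) as well, and this is the only comparison at that second position.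

Going by these compounds, whether the high number goes with the oxygen linking the ring or with the methoxy group stays open, and an unsubstituted phenoxy group and a 2-methoxybenzyl group on this aromatic carbon would separate the two. No measurement shown here gives a cause for any of these steps.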